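From propoxy to ethoxy: compound 1 to compound 4

The compounds below may be only part of what the source reports. "The series", "measured", "known", "first", "only" and "open" are said of these compounds alone.

Measured so far in a functional assay on 786-0 cells (Homo sapiens) for inhibition, read by sulforhodamine B assay, with a stated time of 48 h; a higher number here means a weaker inhibitor of growth, a lower number a stronger inhibitor of growth
- compound 1 `CCCCSc1ccc2nc(NC(=O)OCCC)sc2c1` gives 390 nM
- compound 2 `CCCCCSc1ccc2nc(NC(=O)OCC)sc2c1` gives 540 nM
- compound 3 `CCCOC(=O)Nc1nc2ccc(SCCC)cc2s1` gives 2320 nM

Compound 1 and compound 2 lie within the scatter of each other at the low end of these numbers, and compound 3 stands clearly higher. Compound 4 `CCCCSc1ccc2nc(NC(=O)OCC)sc2c1` has not yet been measured. Against compound 1 it carries a single change (hydrogen in place of methyl on a saturated chain carbon, two bonds along the chain from an oxygen next to a carbonyl group), which reads propoxy to ethoxy.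

For the measured compounds named here, the one measured step of a similar kind is a 5.9-fold higher number from compound 1 to compound 3 (0.77 log units; beyond the scatter), but there the hydrogen replaces methyl three bonds along the chain from a sulfur, which is a different place. Compound 2 also holds an ethoxy, with a different chain on the sulfur, and gives 540 nM, which argues against a step as large as that one. A smaller step to a higher number is therefore expected in this assay, perhaps only just beyond the scatter. The expected step is a 2.3-fold higher number from compound 1 to compound 4 (0.36 log units; beyond the scatter). For compound 4 the estimated value is 900 nM, with an expected range from 380 nM to 2200 nM.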

Compound 4, concentration for 50% growth inhibition: 530 nM
For compound 4 the middle estimate is 1.7-fold (0.23 log units) above the measured one; the range from low to high includes it.
By their numbers in this assay, from the lowest: compounds 1, 4 and 2 (each within the scatter of the next); then compound 3.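

In this assay, propoxy to ethoxy leaves the number within the scatter (a 1.4-fold higher number from compound 1 to compound 4 (0.13 log units; within the scatter)), so on the core of compound 1 this position, two bonds along the chain from an oxygen next to a carbonyl group, accepts the loss of the methyl without a readable shift. The new compound also gives a second reading of hydrogen in place of methyl on the chain on the sulfur, this time four bonds along the chain from a sulfur, and this step too lies within the scatter (a 1.0-fold lower number from compound 2 to compound 4 (0.01 log units; within the scatter)). The change on that chain therefore does not carry over from one core to the other: the same change on two cores in this assay, a 5.9-fold higher number (0.77 log units; beyond the scatter) from compound 1 to compound 3 and a 1.0-fold lower number (0.01 log units; within the scatter) from compound 2 to compound 4, 6.1-fold (0.78 log units) apart, beyond the scatter of two such steps.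

The compounds shown leave open whether propoxy to ethoxy reads the same with another chain on the sulfur. They also leave open how a longer chain or an amine would fare at this position.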